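The compounds below may be only part of what the source reports. "The series", "measured", "known", "first", "only" and "open" are said of these compounds alone.

Of the compounds shown here, three with a shared core have been measured in a functional assay on HeLa cells (Homo sapiens) for antiproliferative activity, read by MTT assay; on this read-out lower numbers stand for stronger inhibition and higher numbers for weaker inhibition. Compound 1 `CN1CCN(c2ccc(Nc3ncc(/N=C/c4cccs4)c(NC4CCCC4)n3)cc2)CC1` carries thiophen-2-yl on the carbon with a double bond to nitrogen; in this assay compound 1 gives 25700 nM. Compound 2 `CN1CCN(c2ccc(Nc3ncc(/N=C/c4ccc(C(F)(F)F)cc4)c(NC4CCCC4)n3)cc2)CC1` carries 4-(trifluoromethyl)phenyl there instead. For compound 2 the result in this assay is only a limit of the assay, > 100000 nM, matching (the limit of > 100000 nM in this assay, at which 1 of the 3 values shown sits). The change amounts to an at least 3.8-fold higher number from compound 1 to compound 2 (0.59 log units; beyond the scatter). Compound 3 `NS(=O)(=O)c1ccc(Nc2ncc(/N=C/c3ccc(C(F)(F)F)cc3)c(NC3CCCC3)n2)cc1` has sulfamoyl in place of 4-methylpiperazin-1-yl on an aromatic carbon; in this assay compound 3 gives 21900 nM, which is an at least 4.5-fold lower number from compound 2 to compound 3 (0.65 log units; beyond the scatter).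

Compound 4 `CC(C)Nc1nc(Nc2ccc(N3CCN(C)CC3)cc2)ncc1/N=C/c1ccc(C(F)(F)F)cc1` has not yet been measured. It differs from compound 2 in one place: isopropyl in place of cyclopentyl on a nitrogen on an aromatic ring. Neither measured step touches this position. The step from compound 1 to compound 2 concerns the group on the carbon with a double bond to nitrogen, and the step from compound 2 to compound 3 the group on the aromatic carbon, so neither gives a direct guide to the size or direction of this change in this assay. Compound 2 stands at the limit. Compound 4 is therefore expected to remain near it, with an expected step that the limit leaves unreadable from compound 2 to compound 4. The estimate for compound 4 in this assay is 120000 nM, within a range from 40000 nM to 300000 nM, with a substantial chance that again only a limit is reported.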

Compound 4, half-maximal inhibitory concentration: > 100000 nM
Compound 4: no number, only a limit; the forecaster's own chance of this, stated with the estimate: 65%; the middle value is on the limit's open side.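

In this assay compound 4 gives > 100000 nM as a limit of the assay, not a number. Compound 2 and compound 4 thus sit at the same limit, and no step between them can be read: the limit of > 100000 nM in this assay, at which 2 of the 4 values shown sit.

The compounds shown leave open whether isopropyl in place of cyclopentyl changes the result in this assay at all, and in which direction.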